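A few compounds are considered here, and "the series" means these few. Any claim that something is new, unique, unknown or untested is made for them only; others in the source may bear on it.

In a functional assay on HepG2 cells (Homo sapiens) for antiproliferative activity, read by MTT assay, with a stated time of 24 h (on this read-out lower numbers stand for stronger inhibition and higher numbers for weaker inhibition), compound 3 (`O=S(=O)(c1ccccc1)n1c(-c2cn(-c3ccccc3)nc2-c2ccc(F)cc2)nc2ccccc21`) gives 720 nM and lies within the scatter of compound 2 (`Cc1ccc(-c2nn(-c3ccccc3)cc2-c2nc3ccccc3n2S(=O)(=O)c2ccccc2)cc1`) at 960 nM on this read-out. Compound 1 (`FC(F)(F)c1ccc(-c2nn(-c3ccccc3)cc2-c2nc3ccccc3[nH]2)cc1`) stands apart at 6030 nM with a clearly higher number than compound 3 shows. Compound 4 (`O=S(=O)(c1ccccc1)n1c(-c2cn(-c3ccccc3)nc2-c2ccc(C(F)(F)F)cc2)nc2ccccc21`) differs from compound 3 in one place, with trifluoromethyl in place of fluoro on an aromatic carbon para to a large group. The cut one bond further out reads 4-fluorophenyl to 4-(trifluoromethyl)phenyl. Going by the values given here, the one measured step at that place is a 1.3-fold lower number from compound 2 to compound 3 (0.12 log units; within the scatter) for fluoro in place of methyl, and this step points to no shift beyond the scatter for a further swap there. Compound 1 also carries the trifluoromethyl group but lacks the phenylsulfonyl group of compound 2 and compound 3. Among the compounds with values here, the data therefore hold no pair that isolates trifluoromethyl with the phenylsulfonyl group present, and the guide remains a single step. The expected step in this assay is a 1.1-fold higher number from compound 3 to compound 4 (0.05 log units; within the scatter) with no firm direction and none expected beyond the scatter. For compound 4 the estimated value is 800 nM with an expected range from 350 nM to 1800 nM on this read-out.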

Compound 4, half-maximal inhibitory concentration: 590 nM
The estimate for compound 4 lay 1.4-fold (0.13 log units) above the measured number, within the range that was stated.
By their numbers in this assay, from the lowest: compounds 4, 3 and 2 (each within the scatter of the next); then compound 1.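

In this assay, the aromatic carbon para to a large group takes trifluoromethyl, with its 4 heavy atoms in place of the 1 of fluoro, without a shift beyond the scatter (a 1.2-fold lower number from compound 3 to compound 4 (0.09 log units; within the scatter)). The step from methyl also stays within the scatter (a 1.6-fold lower number from compound 2 to compound 4 (0.21 log units; within the scatter)), so with phenylsulfonyl on the aromatic nitrogen, methyl, fluoro and trifluoromethyl at this place cannot be told apart on this read-out. Going by these compounds alone, compound 4 also supplies the first pair that isolates the nitrogen substituent: with trifluoromethyl held constant, phenylsulfonyl in place of hydrogen gives a large step beyond the scatter (a 10-fold lower number from compound 1 to compound 4 (1.01 log units; beyond the scatter)), far larger than any step seen so far at the aromatic carbon, and no measurement at hand bears on the reason for either finding.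

From the compounds shown here alone, whether the phenylsulfonyl step carries over to the compounds with fluoro or methyl on the aromatic carbon remains open, as it rests on the trifluoromethyl pair alone. Also open, going by these compounds, is how this carbon responds to an amine or a carboxylic acid, and how the nitrogen responds to a smaller substituent such as methylsulfonyl or acetyl.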